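Replacing Chloro with Phenyl in a Small Cytotoxicity Series

This account rests on a few compounds, and the source may have more. Where it says the series, first, only, none or still open, it means among the compounds named here.

Compound 1 `CS(=O)(=O)c1ccc(Cc2n[nH]c(=S)n2/N=C/c2ccc(Cl)cc2)cc1` was tested in a functional assay on HeLa cells (Homo sapiens) for cytotoxicity, read by MTT assay, with a stated time of 48 h; a higher number here means that more compound is needed for the effect, a lower number that less compound is needed. In this assay compound 1 gives 50000 nM. Within the data shown here, only one other compound has been measured alongside it. Compound 2 `CS(=O)(=O)c1ccc(Cc2n[nH]c(=S)n2/N=C/c2ccccc2F)cc1` carries a 2-fluorophenyl in place of the 4-chlorophenyl of compound 1 on a carbon with a double bond to nitrogen. In this assay compound 2 reaches only a limit, > 100000 nM, so no number is known for it. Among the measured compounds shown here, the single measured step is therefore an at least 2.0-fold higher number from compound 1 to compound 2 (0.30 log units; that floor lies within the scatter), and it rests on (the limit of > 100000 nM in this assay, at which 1 of the 2 values shown sits). For the measured compounds named here, compound 1 thus holds the only actual number in the set.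

Compound 3 `CS(=O)(=O)c1ccc(Cc2n[nH]c(=S)n2/N=C/c2ccc(-c3ccccc3)cc2)cc1` is not yet measured. It differs from compound 1 by phenyl in place of chloro on an aromatic carbon. Going by these compounds, the step from compound 1 to compound 2 swapped one halogenated phenyl for a different one and so speaks only loosely to the change at hand; it pointed toward a weaker compound, but its true size is unknown. With nothing closer to lean on, compound 3 is expected to stay near compound 1, a step of a 1.3-fold lower number from compound 1 to compound 3 (0.10 log units; within the scatter). Compound 3 is estimated at 40000 nM, most likely between 8000 nM and 150000 nM, with a real chance that this assay again returns only a limit.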

Compound 3, half-maximal effective concentration: 50000 nM
Compound 3: the middle estimate sits 1.3-fold (0.10 log units) below what was measured; the measured number falls inside the stated range.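

In this assay, putting phenyl in place of chloro gives no change at the digits printed from compound 1 to compound 3 (within the scatter), so at this aromatic carbon, para to a large group, a whole six-membered aromatic ring of carbon only and a single chlorine atom give matching numbers. Among these compounds, this is the first step in the set with a real number at both ends, since the earlier step ended at a limit and had no known size; here the size of the group that enters, far larger than the one that leaves, does not separate the two compounds in this cell test. Nothing measured here bears on why the two numbers match, so the result stands as an observation without an explanation.

Going by these compounds, both groups that have stood at this position carry no hydrogen-bond donors or acceptors and no net charge, so it remains open whether an amine or a carboxylic acid there would give a different number. On these data alone, it is also open whether a methoxy group, or a second ring joined through a longer chain, would read the same as chloro and phenyl do in this assay.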